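From cyclohexyl to sec-butyl on an amine nitrogen

A few compounds are considered here, and "the series" means these few. Any claim that something is new, unique, unknown or untested is made for them only; others in the source may bear on it.

Measured in an ADME assay on EA.hy 926 cells (Homo sapiens) for inhibition, read by MTT assay, with a stated time of 72 h; a higher number here means a weaker inhibitor, a lower number a stronger inhibitor:
- compound 1 `COc1cc(/C=C/C(=O)/C=C(/C=C/c2ccc(OC(C)=O)c(OC)c2)NC2CCCCC2)ccc1OC(C)=O` gives > 25000 nM
- compound 2 `C=CCNC(=C\C(=O)/C=C/c1ccc(O)c(OC)c1)/C=C/c1ccc(O)c(OC)c1` gives > 25000 nM

Compound 1 has no exact number in this assay, only the limit > 25000 nM. Compound 2 is likewise reported only as a limit, so both compounds sit at the limit of > 25000 nM in this assay, at which 2 of the 2 values shown sit.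

Compound 3 `CCC(C)NC(=C\C(=O)/C=C/c1ccc(OC(C)=O)c(OC)c1)/C=C/c1ccc(OC(C)=O)c(OC)c1` has not yet been measured. It carries sec-butyl in place of cyclohexyl on an amine nitrogen. Among the measured compounds shown here, no measured pair shows what such a change does in this assay, so no step beyond the usual scatter is expected, in either direction. This expectation rests on compound 1 and its limit of > 25000 nM. The estimated step is a number no higher from compound 1 to compound 3 (the limit leaves the size open). Compound 3 is estimated at 25000 nM, with an expected range from 10000 nM to 50000 nM.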

Compound 3, half-maximal inhibitory concentration: > 25000 nM
Compound 3 ended at the assay's limit; the forecaster's own chance of this, stated with the estimate: 70%; the middle value sits exactly at the limit.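

In this assay compound 3 gives > 25000 nM, which is a limit and not a number. Among the compounds shown here, compound 1 is likewise reported only as a limit, so no step between compound 1 and compound 3 can be read. As far as these compounds go, whether sec-butyl in place of cyclohexyl on an amine nitrogen changes inhibition in this assay remains open.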